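The source may hold more compounds than are shown below. What is called first, only, known or untested is meant among the compounds shown, and "the series" means these compounds.

Compound 3 `CCC(C)(C)Cc1c[nH]c(CCc2ccc(-c3cnsc3)cc2)n1` stands second highest of the three numbers in a functional assay on HEK293 cells for agonist activity at Bombesin receptor subtype-3 (Mus musculus), read by luminescence and calcium flux, with a stated time of 10 min (on this read-out higher numbers stand for an effect only at larger amounts of compound and lower numbers for an effect already at smaller amounts), where compound 3 gives 6.9 nM. Its neighbours are compound 1 `CCC(C)(C)Cc1c[nH]c(CCc2ccc(-c3cccnc3)cc2)n1`, which gives 4.3 nM, and compound 2 `CCC(C)(C)Cc1c[nH]c(CCc2ccc(-n3ncnn3)cc2)n1`, which gives 25 nM. The step of a 1.6-fold higher number from compound 1 to compound 3 (0.21 log units; within the scatter) is small, while a 3.6-fold lower number from compound 2 to compound 3 (0.56 log units; beyond the scatter) and a 5.8-fold higher number from compound 1 to compound 2 (0.76 log units; beyond the scatter) show that only the 2H-tetrazol-2-yl group of compound 2 stands apart. Compound 4 `CCC(C)(C)Cc1c[nH]c(CCc2ccc(-c3ccc(F)cn3)cc2)n1` has not been measured yet; it differs from compound 3 as follows: 5-fluoropyridin-2-yl in place of 1,2-thiazol-4-yl on an aromatic carbon. The entering group resembles the pyridin-3-yl of compound 1 more than the 2H-tetrazol-2-yl of compound 2, and the two steps that bear on it, a 1.6-fold higher number from compound 1 to compound 3 (0.21 log units; within the scatter) and a 3.6-fold lower number from compound 2 to compound 3 (0.56 log units; beyond the scatter), suggest that swapping this position among ring groups of this kind moves the number little, apart from the tetrazolyl case. A step within or barely beyond the scatter is therefore expected, in either direction, and the estimated step is a 1.4-fold lower number from compound 3 to compound 4 (0.14 log units; within the scatter). Compound 4 is expected to give 5 nM in this assay, with a range of 2 nM to 15 nM.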

Compound 4, half-maximal effective concentration: 16 nM
Estimate against measurement, compound 4: 3.2-fold (0.51 log units) below, and the stated range ends below it.
By their numbers in this assay, from the lowest: compounds 1 and 3 (each within the scatter of the next); then compounds 4 and 2 (each within the scatter of the next).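

Swapping one ring group for another at this position can matter even without the tetrazolyl group: the 5-fluoropyridin-2-yl group of compound 4 gives a step beyond the scatter against the 1,2-thiazol-4-yl group (a 2.3-fold higher number from compound 3 to compound 4 (0.37 log units; beyond the scatter)). A pyridine ring alone does not hold the number at its low level either, since the step from the pyridin-3-yl group is also beyond the scatter (a 3.7-fold higher number from compound 1 to compound 4 (0.57 log units; beyond the scatter)). The 2H-tetrazol-2-yl group no longer stands apart, as the step between it and the new group lies within the scatter (a 1.6-fold lower number from compound 2 to compound 4 (0.19 log units; within the scatter)).

On these data alone, whether the fluorine or the change from pyridin-3-yl to pyridin-2-yl drives the rise stays open, and a plain pyridin-2-yl group would separate the two. Nothing measured here gives a reason for these steps.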